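The compounds below may be only part of what the source reports. "The series", "measured", "known", "first", "only" and "open" are said of these compounds alone.

Working notes on the series, all read in a functional assay on MIA PaCa-2 cells (Homo sapiens) for inhibition, read by MTT assay, with a stated time of 72 h; a lower number here means a stronger inhibitor, a higher number a weaker inhibitor. Three compounds differ only in the halogen on an aromatic carbon. Compound 1 (`COc1cc(NC(C)CCCNC(=O)NNC(=O)Nc2ccc(F)cc2)c2ncccc2c1`) gives >= 250000 nM, which is a limit and not a number. Compound 2 (`COc1cc(NC(C)CCCNC(=O)NNC(=O)Nc2ccc(Cl)cc2)c2ncccc2c1`) gives >= 250000 nM, again a limit. Within the data shown here, compound 3 (`COc1cc(NC(C)CCCNC(=O)NNC(=O)Nc2ccc(Br)cc2)c2ncccc2c1`) reads 231000 nM, the only true number so far, and the rest of the set is the limit of >= 250000 nM in this assay, at which 2 of the 3 values shown sit.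

The halogen exchanges give a step that the two limits leave unreadable from compound 1 to compound 2, then an at least 1.0-fold lower number from compound 1 to compound 3 (0.03 log units; that floor lies within the scatter), and an at least 1.0-fold lower number from compound 2 to compound 3 (0.03 log units; that floor lies within the scatter). None of these is a readable change beyond the scatter.

Next is compound 4 (`COc1cc(NC(C)CCCNC(=O)NNC(=O)Nc2cccc(Cl)c2)c2ncccc2c1`), with the difference 3-chlorophenyl in place of 4-bromophenyl on an amide-type nitrogen. Among the measured compounds shown here, these halogen exchanges are the only measured steps that bear on it, and no measured compound carries the 3-chlorophenyl group, so they guide the estimate only loosely.

Given an at least 1.0-fold lower number from compound 2 to compound 3 (0.03 log units; that floor lies within the scatter), no step beyond the scatter is expected in this assay, in either direction. The expected change is a 1.0-fold lower number from compound 3 to compound 4 (0.00 log units; within the scatter), which is an estimate. A report as a limit would be no surprise. Compound 4 is expected at 230000 nM, with an estimated range of 120000 nM to 400000 nM.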

Compound 4, half-maximal inhibitory concentration: 74000 nM
The estimate for compound 4 lay 3.1-fold (0.49 log units) above the measured number; measured number outside the range, below it.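

At this position, on an amide-type nitrogen, exchanging one halogen for another in this assay gave no readable change, whereas 3-chlorophenyl in place of 4-bromophenyl gives a 3.1-fold lower number from compound 3 to compound 4 (0.49 log units; beyond the scatter). With the halogen kept, 3-chlorophenyl in place of 4-chlorophenyl gives an at least 3.3-fold lower number from compound 2 to compound 4 (0.52 log units; beyond the scatter), and 3-chlorophenyl in place of 4-fluorophenyl gives an at least 3.3-fold lower number from compound 1 to compound 4 (0.52 log units; beyond the scatter), so among these four compounds the only steps beyond the scatter go with the place of the halogen on the phenyl ring and not with its identity. Those last two steps are floors, as each starts from a limit and not from a number: the limit of >= 250000 nM in this assay, at which 2 of the 4 values shown sit.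

Going by these compounds, whether fluorine or bromine at the place chlorine holds in 3-chlorophenyl would give the same step stays open, so the gain cannot yet be tied to the position alone or to chlorine there. On these data alone, compound 4 reads 74000 nM in this assay; also open is whether a dichlorophenyl group, or a methoxy group or an amine on the phenyl ring, would take that number lower.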